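From propanoyl to a 2-fluorophenyl carbonyl group

The source may hold more compounds than are shown below. What is called first, only, known or untested is meant among the compounds shown, and "the series" means these compounds.

Measured in a functional assay on NCI-H1975 cells (Homo sapiens) for cytotoxicity, read by MTT assay, with a stated time of 72 h (a higher number here means a weaker inhibitor, a lower number a stronger inhibitor), so far
compound 1 `CCN1C/C(=C\c2cc(OC)c(OC)c(OC)c2)C(=O)/C(=C/c2cc(OC)c(OC)c(OC)c2)C1` gives 6500 nM
compound 2 `CCC(=O)N1C/C(=C\c2cc(OC)c(OC)c(OC)c2)C(=O)/C(=C/c2cc(OC)c(OC)c(OC)c2)C1` gives 1700 nM

Of the two, compound 2 holds the lower number at 1700 nM and is the stronger inhibitor of the pair. The next compound, compound 3 `COc1cc(/C=C2\CN(C(=O)c3ccccc3F)C/C(=C\c3cc(OC)c(OC)c(OC)c3)C2=O)cc(OC)c1OC`, keeps the shared core and differs from compound 2 by 2-fluorophenyl in place of ethyl on a carbonyl carbon with 2-fluorophenyl in place of ethyl on a carbonyl carbon. Among the compounds with values here, only one measured step bears on this change. It is a 3.8-fold lower number from compound 1 to compound 2 (0.58 log units; beyond the scatter) and it is modest, with propanoyl in place of ethyl on an amine nitrogen in a ring. Within the data shown here, compound 3 keeps that carbonyl, but no measured compound carries an aromatic ring on it, so the direction is only tentative. The expected step is a 1.4-fold lower number from compound 2 to compound 3 (0.15 log units; within the scatter) and it may not exceed the scatter. For compound 3 the estimate is 1200 nM with an expected range from 400 nM to 3600 nM in this measurement.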

Compound 3, half-maximal inhibitory concentration: 1400 nM
The estimate for compound 3 lay 1.2-fold (0.07 log units) below the measured number; low and high end bracket the measured number.
By their numbers in this assay, from the lowest: compounds 3 and 2 (each within the scatter of the next); then compound 1.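

In this assay, 2-fluorophenyl in place of ethyl on the carbonyl carbon gives a 1.2-fold lower number from compound 2 to compound 3 (0.08 log units; within the scatter) and so no readable difference, even though a six-membered aromatic ring enters at this place. Set against the ethyl on the ring nitrogen of compound 1, the (2-fluorophenyl)carbonyl group gives a 4.6-fold lower number from compound 1 to compound 3 (0.67 log units; beyond the scatter) in the same direction as propanoyl, so both compounds carrying a carbonyl at this nitrogen lie beyond the scatter of compound 1, while the two groups on that carbonyl cannot be told apart. No measured evidence accounts for this result.

Whether the fluorine contributes anything would take a plain phenyl on the same carbonyl carbon to tell. Going by these compounds, it also remains open whether a longer chain or an amine on that carbonyl carbon would move the number beyond the scatter of compound 2 and compound 3.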